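Removing the acetyl from compound 2: what to expect

A few compounds are considered here, and "the series" means these few. Any claim that something is new, unique, unknown or untested is made for them only; others in the source may bear on it.

The series rests on the core shown in compound 1 `CC(=O)O[C@@H]1C[C@@H](C)[C@](O)(CCc2ccoc2)[C@@]2(C)CCCC(C)(C)[C@H]12`. In a functional assay on ZR-75-30 cells (Homo sapiens) for cytotoxicity, read by MTT assay, with a stated time of 72 h (on this read-out lower numbers stand for stronger inhibition and higher numbers for weaker inhibition), compound 1 gives < 5 ug/mL, which is a limit of the assay and not a number. Compound 2 `CC(=O)O[C@@H]1C[C@@H](C)[C@](O)(CCC2=CC(=O)OC2)[C@@]2(C)CCCC(C)(C)[C@H]12` is reached by the change summarised as a step that the two limits leave unreadable from compound 1 to compound 2. In this assay compound 2 gives < 5 ug/mL, again only a limit. Compound 3 `C[C@@H]1CC=C2C(C)(C)CCC[C@]2(C)[C@@]1(O)CCC1=CC(=O)OC1` in this assay gives < 5 ug/mL, also a limit. Among the measured compounds shown here, because of the limit of < 5 ug/mL in this assay, at which 3 of the 3 values shown sit, no measured step in this set has a readable size, and the three compounds cannot be set in any order.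

Compound 4 `C[C@@H]1C[C@@H](O)[C@H]2C(C)(C)CCC[C@]2(C)[C@@]1(O)CCC1=CC(=O)OC1` has not yet been measured. It differs from compound 2 in one place: hydrogen in place of acetyl on an oxygen on a saturated carbon. For the measured compounds named here, no measured pair shows the exchange of acetyl for hydrogen, so nothing bears directly on its size, and the one step that does connect compound 2 to a neighbour, from compound 1, remains unreadable. Compound 4 is therefore expected to sit with its parent, the step from compound 2 to compound 4 in this assay estimated as a step that the limit leaves unreadable from compound 2 to compound 4. The estimated value for compound 4 in this assay is 3 ug/mL, within a range from 0.5 ug/mL to 15 ug/mL.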

Compound 4, half-maximal inhibitory concentration: < 5 ug/mL
Compound 4 gave a limit, no number; the forecaster's own chance of this, stated with the estimate: 60%; the middle value does not contradict the limit.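

Among the compounds shown here, compound 4, like compound 2, gives only a limit, so no step between the two can be read: the limit of < 5 ug/mL in this assay, at which 4 of the 4 values shown sit. The compounds shown leave open whether the change from acetoxy to hydroxy alters the read-out at all, and how the four compounds would rank.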